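A few compounds are considered here, and "the series" means these few. Any claim that something is new, unique, unknown or untested is made for them only; others in the source may bear on it.

In a functional assay on DLD-1 cells (Homo sapiens) for antiproliferative activity, read by CellTiter-Glo, with a stated time of 72 h (a lower number here means a stronger inhibitor, a higher number a weaker inhibitor), compound 1 `CC1CCN(C2CCN(S(=O)(=O)c3cccnc3Cl)CC2)CC1` reaches only a limit, giving > 5000 nM. Compound 2 `CC1CCN(C2CCN(S(=O)(=O)c3ccccc3Br)CC2)CC1` gives 3 nM. Going by the values given here, the step of an at least 1600-fold lower number from compound 1 to compound 2 (3.22 log units; beyond the scatter) is the only measured step, and it rests on (the limit of > 5000 nM in this assay, at which 1 of the 2 values shown sits), so its full size is not known. Compound 2 therefore holds the only number shown; the other value is a limit. Compound 3 `CC1CCN(C2CCN(S(=O)(=O)c3cnc(Cl)s3)CC2)CC1` differs from compound 2 by 2-chloro-1,3-thiazol-5-yl in place of 2-bromophenyl on a sulfonyl sulfur. Among the compounds with values here, the one measured step that bears on this change is an at least 1600-fold lower number from compound 1 to compound 2 (3.22 log units; beyond the scatter), where a chlorine-bearing six-membered heteroaromatic ring on the sulfonyl sulfur sat at the limit while 2-bromophenyl gave the low number. Compound 3 again carries a chlorine-bearing heteroaromatic ring in that place, and a large rise in the number is expected, a 500-fold higher number from compound 2 to compound 3 (2.70 log units; beyond the scatter). Compound 3 is thus estimated at 1500 nM, within 150 nM to 8000 nM, with a fair chance that only a limit is reported.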

Compound 3, half-maximal inhibitory concentration: 1800 nM
Beside the measured number, compound 3's estimate is 1.2-fold (0.08 log units) below it, and the stated range covers the measured number.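

In this assay, the change on the sulfonyl sulfur gives a 600-fold higher number from compound 2 to compound 3 (2.78 log units; beyond the scatter), so the low number of compound 2 does not carry over to a five-membered aromatic ring with 2 hetero atoms. Compound 3 nevertheless gives a measured number in this place, which shows that a chlorine-bearing heteroaromatic ring here need not end at a limit, and the step from the six-membered ring is an at least 2.7-fold lower number from compound 1 to compound 3 (0.44 log units; beyond the scatter). The value of compound 1, > 5000 nM, is a limit, so the full size of that step is not known: the limit of > 5000 nM in this assay, at which 1 of the 3 values shown sits.

Compound 2 differs from compound 1 and compound 3 in both the ring and the halogen, so the compounds shown do not separate the two. As far as these compounds go, whether 2-chlorophenyl or 2-bromopyridin-3-yl on the sulfonyl sulfur would keep the low number of compound 2 remains open.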